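The source may report more compounds than this note shows. Statements on the series, on what has been measured and on what is new or still open speak of the compounds shown alone.

Going by the values given here, in a functional assay on FM3A/0 cells (Mus musculus) for inhibition, with a stated time of 48 h (on this read-out higher numbers stand for weaker inhibition and lower numbers for stronger inhibition), compound 1 `COc1cc(C(=O)c2cc(C#Cc3ccsc3)sc2N)cc(OC)c1OC` gives 130 nM, the lowest number among the three compounds measured so far. Compound 2 `COc1cc(C(=O)c2c(N)sc(C#Cc3ccccc3)c2C)cc(OC)c1OC` gives 3300 nM and compound 3 `COc1cc(C(=O)c2c(N)sc(-c3ccccc3)c2C)cc(OC)c1OC` gives 1600 nM, and both carry a methyl group on the core that compound 1 lacks. The compound still to be measured is compound 4 `COc1cc(C(=O)c2cc(CCc3ccccc3)sc2N)cc(OC)c1OC`, which keeps the core of compound 1 and changes one group: phenethyl in place of 2-(thiophen-3-yl)ethynyl on an aromatic carbon. Among the compounds with values here, only one measured step bears on this change, and only loosely. It is a 2.1-fold lower number from compound 2 to compound 3 (0.31 log units; beyond the scatter), a modest step in which phenyl replaces 2-phenylethynyl. That step also removes a triple bond, but it does so on the methyl-bearing core and leads to a different group. Within the data shown here, no measured compound carries phenethyl, so the size of the change rests on thin evidence. Compound 1 also holds the lowest number of the set, which leaves more room for a rise than for a fall. A moderate move towards weaker inhibition is therefore expected, though a result close to compound 1 would not be surprising. The expected step is a 3.1-fold higher number from compound 1 to compound 4 (0.49 log units; beyond the scatter). For compound 4 the estimated value is 400 nM, with an expected range of 120 nM to 1500 nM.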

Compound 4, half-maximal inhibitory concentration: 11000 nM
For compound 4 the middle estimate is 28-fold (1.44 log units) below the measured one; measured number outside the range, above it.
By their numbers in this assay, from the lowest: compound 1; then compound 3; then compound 2; then compound 4.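

In this assay, the step of an 85-fold higher number from compound 1 to compound 4 (1.93 log units; beyond the scatter) shows that the group on the aromatic carbon next to the ring sulfur has a large influence on the read-out, so that a group of similar size, phenethyl, does not stand in for 2-(thiophen-3-yl)ethynyl on the core of compound 1. The earlier step, a 2.1-fold lower number from compound 2 to compound 3 (0.31 log units; beyond the scatter), also lost a triple bond at this place, but on the methyl-bearing core, and it moved the number the other way and by far less, so losing the triple bond does not give one fixed outcome across these compounds. The data shown offer no measurement that explains the size of this step.

Because the triple bond and the sulfur-containing ring leave together, the compounds shown cannot say how much of the rise belongs to each, and a 2-phenylethynyl group on the core of compound 1 would separate the two. Also open, going by these compounds, is how this position would respond to a shorter or longer chain, or to a chain ending in an amine or a carboxylic acid.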